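From butoxy to hydroxy at the weak end of the series

The source may hold more compounds than are shown below. What is called first, only, known or untested is meant among the compounds shown, and "the series" means these compounds.

Of the compounds shown here, three have values so far. In a functional assay (Homo sapiens) for inhibition (on this read-out higher numbers stand for weaker inhibition and lower numbers for stronger inhibition), compound 1 (`COc1cc(/C=C/C(=O)c2cccc(N(C)C)c2)cc(OC)c1`) reads 5000 nM and compound 2 (`COc1ccc(C(=O)/C=C/c2ccc(F)cc2F)c(OC)c1`) reads 12000 nM on the same scale. Compound 3 (`CCCCOc1ccc(C(=O)/C=C/c2c(OC)cccc2OC)cc1`) reads 127000 nM and holds the highest of the three numbers, which makes it the weakest inhibitor measured here. Its gaps to compound 2 and to compound 1 both lie beyond the scatter.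

The next compound to be read is compound 4 (`COc1cccc(OC)c1/C=C/C(=O)c1ccc(O)cc1`). One change leads to it from compound 3 (hydrogen in place of butyl on an oxygen on an aromatic ring) and that change is hydrogen in place of butyl on an oxygen on an aromatic ring, or butoxy to hydroxy.

Among the compounds with values here, no measured pair isolates this change, so the size of the step is poorly constrained. With compound 3 at 127000 nM at the top of the range seen so far and compound 2 at 12000 nM as its nearest neighbour, a move towards a lower number, meaning stronger inhibition, is expected, and of a size beyond the scatter. The expected change is a 4.2-fold lower number from compound 3 to compound 4 (0.63 log units; beyond the scatter) in this assay with wide uncertainty on it. Compound 4 is estimated at 30000 nM with a range of 8000 nM to 110000 nM expected across repeat measurements.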

Compound 4, half-maximal inhibitory concentration: 60000 nM
For compound 4 the middle estimate is 2.0-fold (0.30 log units) below the measured one; the measured number falls inside the stated range.
By their numbers in this assay, from the lowest: compound 1; then compound 2; then compound 4; then compound 3.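

In this assay, within the data shown here, the butyl on the oxygen on the aromatic ring can go without any loss of inhibition: the butoxy to hydroxy change gives a 2.1-fold lower number from compound 3 to compound 4 (0.33 log units; beyond the scatter) and is the first step that isolates a single place. The step is modest but beyond the scatter, so the butyl chain is not required at this position for the inhibition seen with compound 3, and the hydroxy compound is the stronger of the pair. Nothing measured on this pair bears on why the step has this direction or size.

A single step cannot show whether the gain follows from shortening the chain or from the free hydroxy itself, and a methoxy or a propoxy on the same oxygen would separate the two, as a graded series of chain lengths would show whether the change is stepwise or abrupt. From the compounds shown here alone, it also remains open whether butoxy to hydroxy gives a similar step on the cores of compound 1 and compound 2, or whether an amine or a carboxylic acid in this place would be tolerated.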